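Cyclic acetal on the chain of compound 1

This account rests on a few compounds, and the source may have more. Where it says the series, first, only, none or still open, it means among the compounds named here.

Compound 1 `Cn1c(Cc2nn(C)c(=O)c3ccccc23)nnc1SCC(=O)Nc1ccc(Cl)cc1Cl` gives 22500 nM in an assay on 32D cells for inhibition of interleukin-15 (Mus musculus), read by resazurin assay, with stated times of 30 min and 2.5 days, in the presence of a further agent that is not named here; on this read-out lower numbers stand for stronger inhibition and higher numbers for weaker inhibition.
Compound 2 `Cn1nc(Cc2nnc(SCC(=O)Nc3ccc(Cl)cc3Cl)n2CCC=O)c2ccccc2c1=O` gives 6000 nM in this assay.
Compound 3 `Cn1nc(Cc2nnc(SCC(=O)Nc3ccc(Cl)cc3Cl)n2CCCO)c2ccccc2c1=O` gives only a limit, > 30000 nM, in this assay.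

Of the two numbers shown, compound 1 has the highest; compound 2 stands nearest, with a 3.8-fold lower number from compound 1 to compound 2 (0.57 log units; beyond the scatter). Compound 4 `Cn1c(Cc2nn(CCC3OCCO3)c(=O)c3ccccc23)nnc1SCC(=O)Nc1ccc(Cl)cc1Cl` differs from compound 1 by (1,3-dioxolan-2-yl)methyl in place of hydrogen on a saturated chain carbon bound to an aromatic nitrogen. Two measured steps from compound 1 bear on this change: a 3.8-fold lower number from compound 1 to compound 2 (0.57 log units; beyond the scatter) and an at least 1.3-fold higher number from compound 1 to compound 3 (0.12 log units; that floor lies within the scatter). Compound 3 sits at the limit (the limit of > 30000 nM in this assay, at which 1 of the 3 values shown sits). Between the two chains there is an at least 5.0-fold higher number from compound 2 to compound 3 (0.69 log units; beyond the scatter). Compound 4 carries neither the formyl nor the hydroxyl group, so the expected step is a 1.3-fold lower number from compound 1 to compound 4 (0.10 log units; within the scatter), not beyond the scatter. Compound 4 is estimated at 18000 nM, between 6000 nM and 40000 nM.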

Compound 4, half-maximal inhibitory concentration: > 30000 nM
Compound 4 was reported as a limit (the forecaster's own chance of this, stated with the estimate: 30%); middle value at least 1.6-fold (0.22 log units) away from the limit.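

Compound 4 gives only a limit, not a number, in this assay, and its step is an at least 1.3-fold higher number from compound 1 to compound 4 (0.12 log units; that floor lies within the scatter). Of the changes shown on compound 1, only the one to compound 2 gives a lower number beyond the scatter, while compound 3 and compound 4 do not. The (1,3-dioxolan-2-yl)methyl change thus brings no measurable gain, and compound 4 joins compound 3 at the limit: the limit of > 30000 nM in this assay, at which 2 of the 4 values shown sit.

On these data alone, how far compound 4 truly stands from compound 1 stays open. Also open, as far as these compounds go, is how a chain ending in an amine or a carboxylic acid would read in this assay.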